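A few compounds are considered here, and "the series" means these few. Any claim that something is new, unique, unknown or untested is made for them only; others in the source may bear on it.

Compound 2 `COc1ccc(-c2nc(C(F)(F)F)sc2N2CCN(C(=O)Cn3nc(C)nc3C)[C@H](C)C2)cn1` shows the highest number of the two compounds measured in a functional assay on U2OS cells for antagonist activity at C-X-C chemokine receptor type 3 (Homo sapiens), read by beta-arrestin recruitment; on this read-out higher numbers stand for weaker inhibition and lower numbers for stronger inhibition: compound 2 gives 1170 nM, while compound 1 `COc1ncc(-c2nc(C(F)(F)F)sc2N2CCN(C(=O)Cn3nc(C)nc3C)[C@H](C)C2)cn1` gives 558 nM. Within the data shown here, the one measured step, a 2.1-fold higher number from compound 1 to compound 2 (0.32 log units; beyond the scatter), concerns the swap of the aromatic ring and is beyond the scatter.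

Compound 3 `CCOc1ccc(-c2nc(C(F)(F)F)sc2N2CCN(C(=O)Cn3nc(C)nc3C)[C@H](C)C2)cn1` differs from compound 2 by methyl in place of hydrogen on a saturated chain carbon bound to an oxygen on an aromatic ring. Among the measured compounds shown here, no measured step concerns this kind of change; the only step known, a 2.1-fold higher number from compound 1 to compound 2 (0.32 log units; beyond the scatter), alters a different part of the molecule and does not bear on lengthening the alkoxy chain. The step of a 1.1-fold higher number from compound 2 to compound 3 (0.05 log units; within the scatter) is therefore expected to be modest, most likely within the scatter, with no firm direction. In this assay compound 3 is expected to give about 1300 nM, with a range from 500 nM to 3500 nM.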

Compound 3, half-maximal inhibitory concentration: 505 nM
Estimate against measurement, compound 3: 2.6-fold (0.41 log units) above; the measured number falls inside the stated range.
By their numbers in this assay, from the lowest: compounds 3 and 1 (each within the scatter of the next); then compound 2.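

Moving from methoxy to ethoxy on the pyridine group is not a neutral change in this assay: the added methyl, on a saturated chain carbon bound to an oxygen on an aromatic ring, gives a 2.3-fold lower number from compound 2 to compound 3 (0.36 log units; beyond the scatter). Among these compounds, this is the first sign that the alkoxy chain itself affects the read-out, and not only the aromatic ring that carries it. Set against the 2-methoxypyrimidin-5-yl group, the 6-ethoxypyridin-3-yl group gives a 1.1-fold lower number from compound 1 to compound 3 (0.04 log units; within the scatter), so these two groups cannot be told apart here. Nothing available explains the effect of the added methyl.

Going by these compounds, whether a longer chain such as propoxy, or a branched one such as isopropoxy, would carry the change further remains open, since a single pair defines no trend. Also open, on these data alone, is how a 2-ethoxypyrimidin-5-yl group would compare with compound 1 and compound 3.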